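A few compounds are considered here, and "the series" means these few. Any claim that something is new, unique, unknown or untested is made for them only; others in the source may bear on it.

Going by the values given here, compound 1 `CCOc1ccc(-n2nncc2CN2C(=O)C3(C(C#N)=C(N)Oc4c3c3nc5ccccc5nc3c3ccccc43)c3ccccc32)cc1` is the first of three measured members. In an ADME assay on L02 cells (Homo sapiens) for antiproliferative activity, read by MTT assay, with a stated time of 48 h (on this read-out higher numbers stand for weaker inhibition and lower numbers for stronger inhibition), compound 1 gives only the limit > 50000 nM. Compound 2 `Cc1cc(C)cc(-n2nncc2CN2C(=O)C3(C(C#N)=C(N)Oc4c3c3nc5ccccc5nc3c3ccccc43)c3ccccc32)c1` carries a 3,5-dimethylphenyl in place of the 4-ethoxyphenyl on an aromatic nitrogen, and in this assay compound 2 likewise stops at the limit > 50000 nM. The step that the two limits leave unreadable from compound 1 to compound 2 therefore cannot be read in either direction. Compound 3 `Cc1cccc(-n2nncc2CN2C(=O)C3(C(C#N)=C(N)Oc4c(N)cc5nc6ccccc6nc5c43)c3ccccc32)c1` is the starting point of the present step, and in this assay compound 3 also sits at the limit > 50000 nM, so its standing is known only as a limit, not as a number; all three shown values share (the limit of > 50000 nM in this assay, at which 3 of the 3 values shown sit).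

Compound 4 `N#CC1=C(N)Oc2c(N)cc3nc4ccccc4nc3c2C12C(=O)N(Cc1cnnn1-c1cccc(C(F)(F)F)c1)c1ccccc12` arises from compound 3 by the change (trifluoromethyl in place of methyl on an aromatic carbon), trifluoromethyl in place of methyl on an aromatic carbon, meta to a large group. Among the compounds with values here, no measured step bears on this change, and the one measured step is itself unreadable, so no shift beyond the scatter can be expected in this assay from it. Compound 4 is therefore expected to remain at or near the limit, with an estimated value of 60000 nM within the range 20000 nM to 150000 nM. The step that the limit leaves unreadable from compound 3 to compound 4 that this estimate implies is expected to be none beyond the scatter.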

Compound 4, half-maximal inhibitory concentration: 38100 nM
For compound 4 the middle estimate is 1.6-fold (0.20 log units) above the measured one, within the range that was stated.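

In this assay, compound 4 is the first member of the series shown to give a number rather than a limit, which makes trifluoromethyl in place of methyl the first change here whose step can be read at all: the change gives an at least 1.3-fold lower number from compound 3 to compound 4 (0.11 log units; that floor lies within the scatter). On these data alone, the true size of that step stays unknown, since compound 3 is known only as a limit, and the printed floor alone shows no shift beyond the scatter. A single number does not change the overall picture for the series: the limit of > 50000 nM in this assay, at which 3 of the 4 values shown sit.

The compounds shown leave open whether a chlorine, a methoxy or a carboxylic acid at this same place on the phenyl ring would also give a number rather than a limit. They also leave open how trifluoromethyl would read on the core of compound 1 or compound 2.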